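Ester alkyl variation on the urea-linked amino acid tail

This account rests on a few compounds, and the source may have more. Where it says the series, first, only, none or still open, it means among the compounds named here.

The three measured compounds share one core and differ only in the ester-bearing tail of the urea. Compound 1 `CCOC(=O)CNC(=O)NCc1ccc(C(=O)N2CCCCc3ccccc32)cc1C` gives 140 nM in a functional assay on HEK293 cells for agonist activity at Vasopressin V2 receptor (Homo sapiens), read by a luciferase reporter and cAMP accumulation; a higher number here means that more compound is needed for the effect, a lower number that less compound is needed. Compound 2 `Cc1cc(C(=O)N2CCCCc3ccccc32)ccc1CNC(=O)NCC(=O)OC(C)C` gives 140 nM in this assay, and the step of no change at the digits printed from compound 1 to compound 2 (within the scatter) shows that enlarging the ester alkyl leaves the number where it was. Compound 3 `COC(=O)[C@@H]1CCCN1C(=O)NCc1ccc(C(=O)N2CCCCc3ccccc32)cc1C` gives 100 nM in this assay; its number is the smallest of the three, but the steps of a 1.4-fold lower number from compound 1 to compound 3 (0.15 log units; within the scatter) and a 1.4-fold lower number from compound 2 to compound 3 (0.15 log units; within the scatter) both sit inside the scatter, so compound 3 cannot be set apart from the other two.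

Compound 4 `Cc1cc(C(=O)N2CCCCc3ccccc32)ccc1CNC(=O)N1CCC[C@H]1C(=O)OC(C)C` is compound 3 with the change (isopropyl in place of methyl on an oxygen next to a carbonyl group). Within the data shown here, the only measured step that bears on it is no change at the digits printed from compound 1 to compound 2 (within the scatter), an ester alkyl enlargement at the same kind of oxygen, which gave no movement. The expectation for compound 4 is therefore a step of no change at the digits printed from compound 3 to compound 4 (within the scatter) in this assay, i.e. nothing beyond the scatter. Compound 4 is estimated at 100 nM in this assay, with a range of 50 nM to 200 nM.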

Compound 4, half-maximal effective concentration: 950 nM
Estimate against measurement, compound 4: 9.5-fold (0.98 log units) below, outside the stated range (above it).
By their numbers in this assay, from the lowest: compounds 3, 1 and 2 (each within the scatter of the next); then compound 4.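

In this assay, isopropyl in place of methyl on an oxygen next to a carbonyl group is not a silent change on the 2-(methoxycarbonyl)pyrrolidin-1-yl tail: the result is a 9.5-fold higher number from compound 3 to compound 4 (0.98 log units; beyond the scatter), whereas the ester enlargement on the open-chain tail gave no change at the digits printed from compound 1 to compound 2 (within the scatter). With the isopropyl ester, the ring-bearing tail also separates from the open-chain tails, with a 6.8-fold higher number from compound 2 to compound 4 (0.83 log units; beyond the scatter) and a 6.8-fold higher number from compound 1 to compound 4 (0.83 log units; beyond the scatter), although with the methyl ester compound 3 stayed within the scatter of compound 1 and compound 2, so across these four compounds the effect of the ester alkyl depends on the tail that carries it. Nothing available here accounts for this dependence.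

Still open, on these data alone, is how the number runs between and beyond these two esters on the pyrrolidine tail, for example with an ethyl or a tert-butyl ester. The free carboxylic acid or a primary amide at this position would show whether any ester is needed on this tail at all.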